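A few compounds are considered here, and "the series" means these few. Any claim that something is new, unique, unknown or untested is made for them only; others in the source may bear on it.

The two measured compounds share one core and differ only in the group carried on an amine nitrogen. In an assay on CHO cells for displacement of a labelled ligand from 5-hydroxytryptamine receptor 1B (Homo sapiens) (on this read-out lower numbers stand for stronger inhibition and higher numbers for weaker inhibition), compound 1 `CN(C1CCN(CCCc2c[nH]c3ccc(-n4cnnc4)cc23)CC1)S(=O)(=O)c1ccccc1` gives 10 nM. For the measured compounds named here, compound 2 `CN(Cc1ccc(S(C)(=O)=O)cc1)C1CCN(CCCc2c[nH]c3ccc(-n4cnnc4)cc23)CC1` gives 140 nM in this assay, which puts it at the higher of the two numbers, and the only measured step between them is a 14-fold higher number from compound 1 to compound 2 (1.15 log units; beyond the scatter). Compound 3 `CC(=O)Nc1ccc(CN(C)C2CCN(CCCc3c[nH]c4ccc(-n5cnnc5)cc34)CC2)cc1` has not yet been measured. Its difference from compound 2 is acetamido in place of methylsulfonyl on an aromatic carbon. Going by the values given here, no measured step exchanges a group on this aromatic ring; the single measured step swaps the whole group on the amine nitrogen, so it does not bear on the exchange at hand and offers no guide to direction or size. With nothing to point either way, the expected change is no change at the digits printed from compound 2 to compound 3 (within the scatter), a step that is estimated to stay within the usual scatter. Among the compounds with values here, the estimate for compound 3 in this assay is therefore 140 nM, with a range from 45 nM to 450 nM that allows for the uncertainty of a change with no measured precedent.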

Compound 3, half-maximal inhibitory concentration: 100 nM
Estimate against measurement, compound 3: 1.4-fold (0.15 log units) above; measured number inside the range.
By their numbers in this assay, from the lowest: compound 1; then compounds 3 and 2 (each within the scatter of the next).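

On the ring of the benzyl group, para to a large group, exchanging methylsulfonyl for acetamido gives a 1.4-fold lower number from compound 2 to compound 3 (0.15 log units; within the scatter) in this assay. This place therefore tolerates a swap from a group with 0 hydrogen-bond donors and 2 hydrogen-bond acceptors to one with 1 hydrogen-bond donor and 1 hydrogen-bond acceptor, with no change that can be told from ordinary assay noise. The gap to the sulfonamide persists with the new ring substituent, at a 10-fold higher number from compound 1 to compound 3 (1.00 log units; beyond the scatter), so both substituted benzyl compounds have higher numbers than compound 1, and neither goes against this; no measurement at hand offers an explanation for these results.

As far as these compounds go, whether a carboxylic acid or a primary amine at this same place on the ring would also leave the number within the scatter of compound 2 remains open. So does the value that a plain benzyl group on the amine nitrogen, with no substituent on its ring, would give beside compound 1.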